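Urea substituent change at the piperidine carbamoyl carbon

This account rests on a few compounds, and the source may have more. Where it says the series, first, only, none or still open, it means among the compounds named here.

Measured compounds:
compound 1 `CC(C)OC(=O)N1CCC(COc2ccc(N3CCN(S(=O)(=O)C(C)C)CC3)nc2)CC1`, in a functional assay on CHO-K1 cells for agonist activity at Glucose-dependent insulinotropic receptor (Homo sapiens), read by a luciferase reporter, with a stated time of 5 h (a higher number here means that more compound is needed for the effect, a lower number that less compound is needed), compound 1 gives 300 nM
compound 2 `CCCCS(=O)(=O)N1CCN(c2ccc(OCC3CCN(C(=O)OC(C)C)CC3)cn2)CC1`, in this assay compound 2 gives 100 nM
compound 3 `CCCS(=O)(=O)N1CCN(c2ccc(OCC3CCN(C(=O)NC(C)C)CC3)cn2)CC1`, in this assay compound 3 gives 1000 nM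

Compound 3 stands at the highest number of the three in this assay; its nearest neighbour is compound 1 and its furthest is compound 2, and both gaps are beyond the scatter. Compound 3 differs from compound 1 in two places, so the two values can only be set side by side, not read as a single step.

Compound 4 `CCCS(=O)(=O)N1CCN(c2ccc(OCC3CCN(C(=O)N4CCOCC4)CC3)cn2)CC1` is not yet measured. The change from compound 3 is morpholin-4-yl in place of isopropylamino on a carbonyl carbon. The one step that is shown, a 3.0-fold lower number from compound 1 to compound 2 (0.48 log units; beyond the scatter), alters the group on the sulfonyl sulfur and does not touch the carbonyl carbon, so it does not bear on this change. Going by the values given here, no measured pair informs a urea-substituent exchange at this place. With nothing to lean on, the expectation for compound 4 in this assay is a step of a 1.1-fold lower number from compound 3 to compound 4 (0.05 log units; within the scatter), essentially none beyond the scatter. Compound 4 is therefore estimated at 900 nM, with a range from 300 nM to 3000 nM.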

Compound 4, half-maximal effective concentration: > 10000 nM
Compound 4 gave a limit, no number; the forecaster's own chance of this, stated with the estimate: 10%; at least 11-fold (1.04 log units) between middle value and limit.
By their numbers in this assay, from the lowest: compound 2; then compound 1; then compound 3. At a limit, above all of these: compound 4.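

In this assay, going by these compounds alone, morpholin-4-yl in place of isopropylamino on a carbonyl carbon gives an at least 10-fold higher number from compound 3 to compound 4 (1.00 log units; beyond the scatter), the first single-place reading at this position and one that shows the substituent here is not freely exchangeable. The earlier step, a 3.0-fold lower number from compound 1 to compound 2 (0.48 log units; beyond the scatter), concerned only the group on the sulfonyl sulfur. The result for compound 4 is a limit and not a number: the limit of > 10000 nM in this assay, at which 1 of the 4 values shown sits.

The change swaps a hydrogen-bond donor and an open chain for a six-membered ring with a hydrogen-bond acceptor, and these compounds do not say which of these differences accounts for the step. Open too, as far as these compounds go, is how dimethylamino, piperidin-1-yl or cyclopropylamino would read on the same carbonyl carbon, and whether isopropoxy and isopropylamino differ there with the sulfonyl group held constant.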